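The source may hold more compounds than are shown below. What is called first, only, known or untested is meant among the compounds shown, and "the series" means these compounds.

Measured compounds:
compound 1, `COc1ncc(-c2ccc3ncnc(Nc4ccc(OCCO)cc4)c3c2)cc1NS(=O)(=O)c1ccc(F)cc1F`: 1060 nM in a functional assay on HCT-116 cells (Homo sapiens) for antiproliferative activity, read by sulforhodamine B assay, with a stated time of 72 h; a lower number here means a stronger inhibitor, a higher number a weaker inhibitor
compound 2, `COc1ncc(-c2ccc3ncnc(Nc4ccc(OCCO)c(Cl)c4)c3c2)cc1NS(=O)(=O)c1ccc(F)cc1F`: 7320 nM in this assay

Among the compounds with values here, compound 2 holds the higher of the two numbers; the only step to it, a 6.9-fold higher number from compound 1 to compound 2 (0.84 log units; beyond the scatter), lies beyond the scatter, so compound 2 is the weaker inhibitor of the pair in this assay. Compound 3, `COc1cc(Nc2ncnc3ccc(-c4cnc(OC)c(NS(=O)(=O)c5ccc(F)cc5F)c4)cc23)ccc1OCCO`, is not yet measured. It differs from compound 2 by methoxy in place of chloro on an aromatic carbon. Within the data shown here, the one measured step that bears on this place is a 6.9-fold higher number from compound 1 to compound 2 (0.84 log units; beyond the scatter), where a chloro entering at the same place raised the number. Among the measured compounds shown here, no measured compound carries a methoxy at this place, so the data give no direct reading of that group; the step from compound 2 to compound 3 removes the chloro that went with the higher number of compound 2 but puts another group in its stead. The expectation is therefore a partial return toward the number of compound 1 rather than a full one: a 2.4-fold lower number from compound 2 to compound 3 (0.39 log units; beyond the scatter). For compound 3 in this assay the estimate is 3000 nM, with a range from 1000 nM to 12000 nM.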

Compound 3, half-maximal inhibitory concentration: 5720 nM
Estimate against measurement, compound 3: 1.9-fold (0.28 log units) below, within the range that was stated.
By their numbers in this assay, from the lowest: compound 1; then compounds 3 and 2 (each within the scatter of the next).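

In this assay, methoxy in place of chloro on this aromatic carbon gives a 1.3-fold lower number from compound 2 to compound 3 (0.11 log units; within the scatter), so the two groups cannot be told apart at this position. Methoxy in place of hydrogen gives a 5.4-fold higher number from compound 1 to compound 3 (0.73 log units; beyond the scatter), which shows that the higher number is not specific to chloro: both groups on this carbon, ortho to the 2-hydroxyethoxy group, go with a higher number than the hydrogen of compound 1, and no compound shown goes against this, though two substituents make a narrow basis for any pattern. No measurement on these compounds offers an explanation for this shared result.

Open, as far as these compounds go, is whether any group on this carbon can match the hydrogen of compound 1, or whether a fluoro, a methyl or an amine would also go with a higher number. Also open, from the compounds shown here alone, is whether the same reading holds when a longer chain or a carboxylic acid stands in place of the 2-hydroxyethoxy group.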